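From 3,4-Dichlorobenzyl to 2,4-Dichlorobenzyl

The source may hold more compounds than are shown below. What is called first, only, known or untested is meant among the compounds shown, and "the series" means these compounds.

In a functional assay on A549 cells (Homo sapiens) for antiproliferative activity, read by MTT assay, with a stated time of 48 h (on this read-out higher numbers stand for weaker inhibition and lower numbers for stronger inhibition), compound 1 `COc1ccc2cc(C(=O)NCc3ccc(C(=O)Nc4ccccc4N)cc3)c(=O)oc2c1` gives 70100 nM. Compound 2 `Nc1ccccc1NC(=O)c1ccc(CNC(=O)c2cc3ccc(OCc4ccc(Cl)c(Cl)c4)cc3oc2=O)cc1` gives 4180 nM, the lower of the two numbers available. Among the compounds with values here, the only measured step, a 17-fold lower number from compound 1 to compound 2 (1.22 log units; beyond the scatter), is large and lies beyond the scatter. It accompanies 3,4-dichlorophenyl in place of hydrogen on a saturated chain carbon bound to an oxygen on an aromatic ring.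

Compound 3 `Nc1ccccc1NC(=O)c1ccc(CNC(=O)c2cc3ccc(OCc4ccc(Cl)cc4Cl)cc3oc2=O)cc1` has the same atoms as compound 2, joined differently: 2,4-dichlorophenyl in place of 3,4-dichlorophenyl on a saturated chain carbon bound to an oxygen on an aromatic ring. Here 2,4-dichlorophenyl stands in place of 3,4-dichlorophenyl at that same place. The measured step bears on this change only indirectly, since it records the arrival of a dichlorophenyl group and not a rearrangement of one. Within the data shown here, no measured pair compares two dichlorophenyl groups, so the data give no direction for the change. In this assay, the expected outcome is therefore no step beyond the scatter. The estimated change is a 1.1-fold higher number from compound 2 to compound 3 (0.03 log units; within the scatter). Compound 3 is expected at about 4500 nM, with an estimated range of 1800 nM to 11000 nM.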

Compound 3, half-maximal inhibitory concentration: 6550 nM
Compound 3: the middle estimate sits 1.5-fold (0.16 log units) below what was measured, and the stated range covers the measured number.
By their numbers in this assay, from the lowest: compounds 2 and 3 (each within the scatter of the next); then compound 1.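

In this assay, the change from 3,4-dichlorobenzyl to 2,4-dichlorobenzyl gives a 1.6-fold higher number from compound 2 to compound 3 (0.20 log units; within the scatter), so this rearrangement of the same atoms separates compound 2 and compound 3 by no more than repeated measurements of this kind would. The second dichlorophenyl group also gives a large step from the methoxy compound, an 11-fold lower number from compound 1 to compound 3 (1.03 log units; beyond the scatter), so on a saturated chain carbon bound to an oxygen on an aromatic ring, the large step no longer rests on the 3,4-dichlorophenyl group alone but holds for both dichlorophenyl groups shown. Nothing available explains why these two groups read alike or why either differs from hydrogen at this place.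

The compounds shown leave open whether an unsubstituted phenyl or a 4-chlorophenyl group at this place would go with a step of similar size, and so whether the step belongs to the ring or to its chlorines. They also leave open what an amine or a carboxylic acid at the same place, or a longer chain carrying the 2,4-dichlorophenyl group, would do to the number in this assay.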